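Fluoro for hydrogen on the fused benzene ring of compound 2

A few compounds are considered here, and "the series" means these few. Any claim that something is new, unique, unknown or untested is made for them only; others in the source may bear on it.

Measured so far in a functional assay on LNCaP C4-2 cells (Homo sapiens) for inhibition, read by MTT assay, with a stated time of 48 h; a higher number here means a weaker inhibitor, a lower number a stronger inhibitor:
compound 1, `COc1ccc2c(C3CC(c4ccncc4)=NO3)c[nH]c2c1`: 3500 nM
compound 2, `c1ccc2c(C3CC(c4ccncc4)=NO3)c[nH]c2c1`: 12800 nM
compound 3, `COc1ccc2[nH]cc(C3CC(c4ccncc4)=NO3)c2c1`: a limit of the assay, > 100000 nM

Compound 2 holds the highest of the two numbers shown in this assay; its nearest neighbour is compound 1, with the step of a 3.7-fold higher number from compound 1 to compound 2 (0.56 log units; beyond the scatter) recorded between them. For compound 3 the value is a limit, (the limit of > 100000 nM in this assay, at which 1 of the 3 values shown sits), and no number is known.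

Compound 4, `Fc1ccc2c(C3CC(c4ccncc4)=NO3)c[nH]c2c1`, differs from compound 2 by fluoro in place of hydrogen on an aromatic carbon. This is the same carbon that carries the methoxy group in compound 1, so the step of a 3.7-fold higher number from compound 1 to compound 2 (0.56 log units; beyond the scatter) is the one that bears on it: putting a group there lowered the number modestly. The step of an at least 7.8-fold higher number from compound 2 to compound 3 (0.89 log units; beyond the scatter) concerns a methoxy on a different carbon and is of less direct use.

A fluoro group is not a methoxy group, so only part of that effect is assumed. Compound 4 is therefore expected to show a modest drop, a 1.8-fold lower number from compound 2 to compound 4 (0.26 log units; within the scatter), in this assay. The estimate for compound 4 is 7000 nM, within 2500 nM to 20000 nM.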

Compound 4, half-maximal inhibitory concentration: 8000 nM
Compound 4: the middle estimate sits 1.1-fold (0.06 log units) below what was measured; low and high end bracket the measured number.
By their numbers in this assay, from the lowest: compound 1; then compounds 4 and 2 (each within the scatter of the next). At a limit, above all of these: compound 3.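

In this assay fluoro on this carbon, meta to a fused ring and para to a fused ring, gives a 1.6-fold lower number from compound 2 to compound 4 (0.20 log units; within the scatter) and so cannot be told apart from hydrogen there. Exchanging the two groups at this carbon gives a 2.3-fold higher number from compound 1 to compound 4 (0.36 log units; beyond the scatter) and separates fluoro from methoxy beyond the scatter. Of the two groups, only methoxy is set apart from hydrogen at this position, so the outcome here depends on the group placed on this carbon, not merely on hydrogen being replaced.

Going by these compounds, whether an amine, a hydroxyl or a longer alkoxy chain on this carbon would track methoxy or fluoro remains open. Nothing measured here accounts for the difference between fluoro and methoxy at this carbon.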